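Swapping Fluoro for Bromo on a Shared Hydrazide Core

This account rests on a few compounds, and the source may have more. Where it says the series, first, only, none or still open, it means among the compounds named here.

The measured compounds and their values:

compound 1 `Cc1ccc(/C=C/C(=O)NNC(=O)c2ccc3c(c2)OCCO3)cc1`: 1050 nM
compound 2 `COc1ccc(/C=C/C(=O)NNC(=O)c2ccc3c(c2)OCCO3)cc1`: 930 nM
compound 3 `O=C(/C=C/c1ccc(F)cc1)NNC(=O)c1ccc2c(c1)OCCO2`: 990 nM

All three share one core and differ only in the group on one aromatic carbon. In a functional assay on cells (Cancer cell lines, Homo sapiens) for inhibition, read by MTT assay, with a stated time of 48 h (on this read-out higher numbers stand for weaker inhibition and lower numbers for stronger inhibition), compound 3 gives 990 nM, which is the second highest of the three numbers; the step of a 1.1-fold lower number from compound 1 to compound 3 (0.03 log units; within the scatter) and the step of a 1.1-fold higher number from compound 2 to compound 3 (0.03 log units; within the scatter) both stay within the scatter, so the three compounds cannot be told apart on these data.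

Compound 4 `O=C(/C=C/c1ccc(Br)cc1)NNC(=O)c1ccc2c(c1)OCCO2` has not yet been measured. It differs from compound 3 by bromo in place of fluoro on an aromatic carbon. Among the measured compounds shown here, the steps that bear on this change are the three substituent swaps on the same aromatic carbon: a 1.1-fold lower number from compound 1 to compound 2 (0.05 log units; within the scatter), a 1.1-fold lower number from compound 1 to compound 3 (0.03 log units; within the scatter) and a 1.1-fold higher number from compound 2 to compound 3 (0.03 log units; within the scatter). Each of them lies within the scatter, so exchanging one small group for another at this place has so far moved the number by no meaningful amount. For the measured compounds named here, no bromo compound has been measured, so the expectation rests on these three swaps alone.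

The step of a 1.0-fold lower number from compound 3 to compound 4 (0.02 log units; within the scatter) is therefore expected to stay within the scatter. Compound 4 is estimated at 950 nM in this assay, with a range from 480 nM to 1900 nM.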

Compound 4, half-maximal inhibitory concentration: 2330 nM
Compound 4: the middle estimate sits 2.5-fold (0.39 log units) below what was measured; measured number above the stated range.
By their numbers in this assay, from the lowest: compounds 2, 3 and 1 (each within the scatter of the next); then compound 4.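

In this assay, the carbon para to a large group turns out not to be indifferent to what it carries: there is a 2.4-fold higher number from compound 3 to compound 4 (0.37 log units; beyond the scatter) and a 2.5-fold higher number from compound 2 to compound 4 (0.40 log units; beyond the scatter) and a 2.2-fold higher number from compound 1 to compound 4 (0.35 log units; beyond the scatter), and all three steps lie beyond the scatter. Methyl, methoxy and fluoro could not be told apart at this carbon, so the earlier compounds gave the impression that a swap here changes little, whereas bromo separates compound 4 from all three and makes it the weakest inhibitor of the four. Nothing available here explains why this one swap moves the number when the others do not.

The compounds shown leave open whether this shift is particular to bromo or also appears with other groups on the same carbon, such as chloro, iodo, an amine or a carboxylic acid. They also leave open whether any group at this carbon can give stronger inhibition than compounds 1, 2 and 3, which remain within the scatter of one another.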